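The source may report more compounds than this note shows. Statements on the series, on what has been measured and on what is new or still open speak of the compounds shown alone.

Measured in a functional assay on A-375 cells (Homo sapiens) for cytotoxicity, read by sulforhodamine B assay, with a stated time of 48 h; on this read-out higher numbers stand for weaker inhibition and lower numbers for stronger inhibition:
- Compound 1 `O=[N+]([O-])c1ccc(-c2nccn2S(=O)(=O)c2ccccc2)cc1`: > 10000 nM, a limit
- Compound 2 `O=S(=O)(c1ccccc1)n1ccnc1-c1ccc(OCc2ccccc2)cc1`: > 10000 nM, a limit

Compound 2 gives no number, only the limit > 10000 nM. Both measured compounds sit at the limit of > 10000 nM in this assay, at which 2 of the 2 values shown sit. Compound 3 `O=S(=O)(c1ccccc1)n1ccnc1-c1ccccc1` carries hydrogen in place of benzyloxy on an aromatic carbon, para to a large group: hydrogen in place of benzyloxy on an aromatic carbon. Among the measured compounds shown here, the only measured step, a step that the two limits leave unreadable from compound 1 to compound 2, concerns the same place, but its size cannot be read. It therefore gives no ground to expect a change beyond the scatter in this assay. The expected step is a step that the limit leaves unreadable from compound 2 to compound 3. Compound 3 is estimated at 12000 nM, with an expected range from 5000 nM to 30000 nM, and it may well be reported only as a limit.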

Compound 3, half-maximal inhibitory concentration: > 10000 nM
Compound 3: only a limit was reported; the forecaster's own chance of this, stated with the estimate: 80%; the middle value lies beyond the limit too.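

Among the compounds shown here, no step among compound 1, compound 2 and compound 3 can be read in this assay, as each gives only a limit: the limit of > 10000 nM in this assay, at which 3 of the 3 values shown sit. The compounds shown leave open whether the group on that aromatic carbon matters at all.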